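The source may hold more compounds than are shown below. What is called first, only, known or untested is meant among the compounds shown, and "the series" means these compounds.

Measured compounds in an ADME assay for permeability, using PAMPA; a lower number here means that the compound crosses the layer more slowly, a higher number that the compound crosses the layer faster:
- compound 1, `O=C(Nc1ccccc1Cl)c1cc(Cl)ccc1O`, gives 118 10^-6 cm/s
- compound 2, `N#Cc1ccc(NC(=O)c2cc(Cl)ccc2O)c(Cl)c1`, gives 5.1 10^-6 cm/s
- compound 3, `O=C(Nc1ccc(C(F)(F)F)cc1Cl)c1cc(Cl)ccc1O`, gives "not determined" (no result reported), so no number was reported for it in this assay

Going by the values given here, compound 3 therefore stands nowhere on the scale: its apparent permeability is simply absent, and no step from it can be counted. The next compound, compound 4, `O=C(Nc1ccc(Cl)cc1Cl)c1cc(Cl)ccc1O`, differs from compound 3 in one place: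

chloro in place of trifluoromethyl on an aromatic carbon

Among the compounds with values here, the one step measured so far in this assay, a 23-fold lower number from compound 1 to compound 2 (1.36 log units; beyond the scatter), concerns a different change, namely cyano in place of hydrogen on an aromatic carbon, and does not involve a chloro or a trifluoromethyl group. It is of no direct use for the step from compound 3 to compound 4. What remains is that compound 4 carries the same shared core as compound 1 with one chloro group added on the aniline-side ring, and compound 1 sits high in this assay. Within the data shown here, with no reading for compound 3 and no step covering the present change, the expected size of the step from compound 3 to compound 4 cannot be stated; the estimate for compound 4 rests on compound 1 alone.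

Compound 4 is expected to give about 80 10^-6 cm/s in this assay, within a range of 25 10^-6 cm/s to 200 10^-6 cm/s.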

Compound 4, apparent permeability: < 22.4 10^-6 cm/s
Compound 4 ended at the assay's limit; the forecaster's own chance of this, stated with the estimate: 5%; at least 3.5-fold (0.55 log units) between middle value and limit.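

In this assay compound 4 gives < 22.4 10^-6 cm/s, which is a limit of the assay and not a number. Chloro in place of hydrogen on the core of compound 1 gives an at least 5.2-fold lower number from compound 1 to compound 4 (0.72 log units; beyond the scatter), so a second group at this position goes with a lower number, after cyano with a 23-fold lower number from compound 1 to compound 2 (1.36 log units; beyond the scatter), and the earlier compounds had shown this for cyano only. The step from compound 2 to compound 4 cannot be read, so chloro and cyano cannot be ranked against each other at this position, because the value of compound 4 is bounded on one side only: the limit of < 22.4 10^-6 cm/s in this assay, at which 1 of the 4 values shown sits.

Trifluoromethyl at this position stays unplaced, since compound 3 has no reading, so the pattern of a lower number rests on compound 2 and compound 4 alone, and how far compound 4 lies past its limit also remains open. The compounds shown also leave open whether a methyl, a methoxy or an amine at this position would keep the number close to that of compound 1, or whether any group placed there goes with a drop of this size.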